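The source may report more compounds than this note shows. Statements on the series, on what has been measured and on what is new or still open speak of the compounds shown alone.

Measured values in a physicochemical assay for lipophilicity, read by HPLC, measured as chromatographic lipophilicity, at pH 7.4; a lower number here means a more polar compound, a higher number a more lipophilic compound:
compound 1 `O=C(C1CCOCC1)N1N=CCC1c1ccccc1` gives 3.1
compound 2 `O=C(c1ccccc1)N1N=CCC1c1ccccc1` gives 4.6
compound 3 `CC(C)(C)C(=O)N1N=CCC1C1CCCCC1` gives 7.3

Compound 2 holds the second highest of the three numbers in this assay. Among the measured compounds shown here, its nearest neighbour is compound 1, which sits lower, and the one measured step, a number 1.50 log units higher from compound 1 to compound 2 (beyond the scatter), covers exactly that gap. For the measured compounds named here, compound 3 stands furthest away and higher; no single-point step joins it to compound 2, so only the two values themselves can be compared.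

The unmeasured compound 4 `O=C(c1cccnc1)N1N=CCC1c1ccccc1` differs from compound 2 in one place:
pyridin-3-yl in place of phenyl on a carbonyl carbon
Going by the values given here, no measured step exchanges a phenyl for a pyridin-3-yl, so the only step that bears on this position is a number 1.50 log units higher from compound 1 to compound 2 (beyond the scatter), which shows that a change of the group on this carbonyl carbon can move the number by a large amount. The entering pyridin-3-yl counts one hydrogen-bond acceptor where the leaving phenyl counts none. A step downward in this assay is therefore expected, smaller than the measured step at the same position but beyond the scatter.

Compound 4 is estimated at 3.4, within 2.8 to 4. The expected step is a number 1.20 log units lower from compound 2 to compound 4 (beyond the scatter).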

Compound 4, distribution coefficient: 2.7
Beside the measured number, compound 4's estimate is 0.70 log units above it; measured number outside the range, below it.
By their numbers in this assay, from the lowest: compound 4; then compound 1; then compound 2; then compound 3.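

In this assay, the exchange on a carbonyl carbon gives a number 1.90 log units lower from compound 2 to compound 4 (beyond the scatter), so a large move at this position does not need a change of ring type as large as the one from oxan-4-yl to phenyl: here the heavy-atom count stays the same, and one ring carbon gives way to one nitrogen. Pyridin-3-yl also falls under the saturated oxan-4-yl, with a number 0.40 log units lower from compound 1 to compound 4 (beyond the scatter), so the three groups on this carbonyl carbon now rank, from the lowest number, pyridin-3-yl, oxan-4-yl, phenyl, with every step between them beyond the scatter. Nothing shown gives a measured reason for the size or the direction of these steps.

From the compounds shown here alone, whether pyridin-4-yl, pyridin-2-yl or a pyrimidine ring on this carbonyl carbon would land near pyridin-3-yl stays open, as does the effect of an amine or a carboxylic acid carried on the ring. Compound 3 differs from compound 2 in more than one place, so whether the exchange of phenyl for pyridin-3-yl would give a similar step with other groups elsewhere on the core cannot be read.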